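Swapping Isopropyl for an Amide-Bearing Chain

The compounds below may be only part of what the source reports. "The series", "measured", "known", "first", "only" and "open" are said of these compounds alone.

Of the compounds shown here, three sharing one core have been tested in an assay on isolated protein (strain Sprague-Dawley) for inhibition of Amine oxidase [flavin-containing] A (Rattus norvegicus), read by spectrophotometry, with a stated time of 5 min, tested at 10 uM; on this read-out lower numbers stand for less inhibition and higher numbers for more inhibition at the one concentration tested (going by the name of the read-out). Compound 1 `O=c1cc(O)c2ccc(OCc3cccc(Br)c3)cc2o1` gives 0%, compound 2 `CCOc1cc(=O)oc2cc(OCc3cccc(F)c3)ccc12` gives 25%, and compound 3 `CC(C)Oc1cc(=O)oc2cc(OCc3cccc(Cl)c3)ccc12` gives 3%. Compound 3 stands second highest of these three numbers: it lies within the scatter of compound 1, while compound 2 sits beyond the scatter, clearly higher.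

Compound 4 `O=C(COc1cc(=O)oc2cc(OCc3cccc(Cl)c3)ccc12)N1CCCCC1` has not yet been measured. The change from compound 3 is ((piperidin-1-yl)carbonyl)methyl in place of isopropyl on an oxygen on an aromatic ring. Among the measured compounds shown here, no step between two measured compounds exists here, so the expected size in this assay rests only on the weak numbers seen so far: a small step, in either direction, not beyond the scatter. Compound 4 is therefore expected to give 8%, ranging from 0% to 30%. This means an estimated step of a number 5 percentage points higher from compound 3 to compound 4 (within the scatter).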

Compound 4, a percentage reported as inhibition, at one concentration (the size of the read-out at that concentration, not a potency): 9%
Compound 4: the middle estimate sits 1 percentage points below what was measured, and the stated range covers the measured number.
By their numbers in this assay, from the lowest: compounds 1, 3 and 4 (each within the scatter of the next); then compound 2.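

Among the compounds shown here, this is the first direct comparison at this position: in this assay, ((piperidin-1-yl)carbonyl)methyl in place of isopropyl on an oxygen on an aromatic ring gives a number 6 percentage points higher from compound 3 to compound 4 (within the scatter). The larger chain, with its added ring and carbonyl, therefore gives a number that cannot be told apart from that of isopropyl. No measurement shown offers an explanation for this result. Still open, as far as these compounds go, is whether a carboxylic acid or an amine on this chain would shift the number beyond the usual scatter.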